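Methoxy for methylsulfanyl on a cytotoxicity core

This account rests on a few compounds, and the source may have more. Where it says the series, first, only, none or still open, it means among the compounds named here.

Compound 1 `CSc1ccc(CNc2nc(SC)nc3ncccc23)cc1` has the lower of the two numbers measured in an ADME assay on 184B5 cells (Homo sapiens) for cytotoxicity, read by MTT assay, with a stated time of 72 h; a lower number here means a stronger inhibitor of growth, a higher number a weaker inhibitor of growth: compound 1 gives 1140 nM. Compound 2 `C[Se]c1nc(N)c2ccccc2n1` gives 59000 nM in this assay, a number well beyond the scatter above that of compound 1. Compound 3 `COc1ccc(CNc2nc(SC)nc3ncccc23)cc1` differs from compound 1 in one place: methoxy in place of methylsulfanyl on an aromatic carbon. For the measured compounds named here, no measured pair shows this exchange, so the step is expected to be small, most likely within the scatter, with no firm direction. The step from compound 1 to compound 3 in this assay is expected to be about a 1.3-fold higher number from compound 1 to compound 3 (0.12 log units; within the scatter). Compound 3 is therefore estimated at 1500 nM, within a range of 500 nM to 4500 nM.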

Compound 3, concentration for total growth inhibition: 69800 nM
Beside the measured number, compound 3's estimate is 47-fold (1.67 log units) below it; the measured number lies above the stated range.
By their numbers in this assay, from the lowest: compound 1; then compounds 2 and 3 (each within the scatter of the next).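

In this assay the exchange of methylsulfanyl for methoxy, on an aromatic carbon para to a large group, gives a 61-fold higher number from compound 1 to compound 3 (1.79 log units; beyond the scatter) and so is far from a neutral swap at this position. The two groups match in heavy atom count, donors and acceptors, and differ in sulfur against oxygen, so these counts do not predict the step here. Nothing measured alongside these numbers bears on why the step is so large. Left open is how an amine or a longer chain such as ethylsulfanyl would fare at this position.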